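This account rests on a few compounds, and the source may have more. Where it says the series, first, only, none or still open, it means among the compounds named here.

Of the compounds shown here, two have been measured so far. In a functional assay on CHO cells for agonist activity at Free fatty acid receptor 1 (Homo sapiens), read by calcium flux (on this read-out higher numbers stand for an effect only at larger amounts of compound and lower numbers for an effect already at smaller amounts), compound 1 `Cc1cccc(C)c1-c1cccc(COc2ccc(CC(F)C(=O)O)cn2)c1` gives 8.6 nM, and compound 2 `CCOC(CC(=O)O)c1ccc(OCc2cccc(-c3c(C)cccc3C)c2)nc1` gives 14 nM. Compound 2 thus stands at the higher of the two numbers, yet the step of a 1.6-fold higher number from compound 1 to compound 2 (0.21 log units; within the scatter) lies within the scatter, so the two are not truly distinguishable. Compound 3 `CCOC(CC(=O)O)c1ccc(OCc2ccccc2)nc1` differs from compound 2 by hydrogen in place of 2,6-dimethylphenyl on an aromatic carbon. Among the measured compounds shown here, no measured step touches this part of the molecule; the single known step alters only the acid-bearing side chain. Compound 3 is therefore expected to show a large rise, a 140-fold higher number from compound 2 to compound 3 (2.15 log units; beyond the scatter), to an estimated 2000 nM with a range from 300 nM to 15000 nM.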

Compound 3, half-maximal effective concentration in the Free fatty acid receptor 1 assay: 230 nM
Compound 3: middle estimate off by 8.7-fold (0.94 log units), on the high side; measured number below the stated range.
By their numbers in the Free fatty acid receptor 1 assay, from the lowest: compounds 1 and 2 (each within the scatter of the next); then compound 3.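

Until now only the acid-bearing side chain had changed, with no step beyond the scatter; this position carries much more weight, as removing the 2,6-dimethylphenyl in favour of hydrogen gives, in the Free fatty acid receptor 1 assay, a 16-fold higher number from compound 2 to compound 3 (1.22 log units; beyond the scatter). The same change also lowers lipophilicity sharply, as a physicochemical assay for lipophilicity, at pH 7.4 (on this read-out lower numbers stand for lower lipophilicity and higher numbers for higher lipophilicity), records: the measured distribution coefficient of compound 2, 2.8, and of compound 3, 0.7, a number 2.10 log units lower (beyond the scatter). In the physicochemical assay compound 2 gives 2.8 and compound 3 gives 0.7.

Going by these compounds, with only hydrogen and 2,6-dimethylphenyl compared at this place, the share of the ring and the share of its two methyl groups stay unknown. On these data alone, whether a plain phenyl or an amine here would hold the low number also remains open.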